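A few compounds are considered here, and "the series" means these few. Any claim that something is new, unique, unknown or untested is made for them only; others in the source may bear on it.

Measured compounds:
compound 1 `CCCCC[Se]c1nc([Se]CCCCC)c2cccnc2n1` – 15200 nM
compound 2 `CSc1ccc(CNc2nc(SC)nc3ncccc23)cc1` – 3280 nM
compound 3 `CCCCC[Se]c1nc([Se]CCCCC)c2ccccc2n1` – > 100000 nM

In a functional assay on HTB-54 cells (Homo sapiens) for cytotoxicity, read by MTT assay, with a stated time of 72 h (a lower number here means a stronger inhibitor of growth, a higher number a weaker inhibitor of growth), compound 1 gives 15200 nM. Among the two numbers shown, that of compound 1 is the highest; the nearest is compound 2, whose number is lower by a margin beyond the usual scatter. For compound 3 this assay reports only a limit, (the limit of > 100000 nM in this assay, at which 1 of the 3 values shown sits), and no number.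

Compound 4 `CCCCC[Se]c1nc(N)c2cccnc2n1` is not yet measured. It differs from compound 1 in one place: one nitrogen atom in place of a group of 6 heavy atoms (5 carbon, 1 selenium; no ring), on an aromatic carbon. In words, one nitrogen atom stands in place of a group of six heavy atoms, five carbon and one selenium, on an aromatic carbon next to the ring nitrogen and ortho to a fused ring.

Among the measured compounds shown here, no measured pair shows what this change does, so the expected step rests on compound 1 alone and is taken as small: from compound 1 the step to compound 4 is estimated as a 1.3-fold higher number from compound 1 to compound 4 (0.12 log units; within the scatter), in no clear direction beyond the scatter. Compound 4 is therefore expected to give about 20000 nM, within a range from 5000 nM to 80000 nM.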

Compound 4, concentration for 50% growth inhibition: 8780 nM
Compound 4: the middle estimate sits 2.3-fold (0.36 log units) above what was measured; the range from low to high includes it.
By their numbers in this assay, from the lowest: compound 2; then compounds 4 and 1 (each within the scatter of the next). At a limit, above all of these: compound 3.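

Among the compounds shown here, the earlier compounds offered no pair differing in one place, so this is the first reading of this position in this assay: the amino group in place of the group of 6 heavy atoms gives a 1.7-fold lower number from compound 1 to compound 4 (0.24 log units; within the scatter). In this one case, the much smaller amino group serves as well as the selenium-bearing chain it replaces, so this chain is not needed at this position to keep the number of compound 1 within the usual scatter. Nothing measured here explains why the swap leaves the number within the scatter.

From the compounds shown here alone, whether a dimethylamine, a carboxylic acid or a longer chain at this position would behave the same remains open. Also open, going by these compounds, is whether the same swap on compound 3, whose value is only a limit, would give a measurable number.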